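The compounds below may be only part of what the source reports. "The series", "measured", "known", "first", "only" and "open" are said of these compounds alone.

Compound 1 `Cc1ccc(-n2nccn2)c(C(=O)N2C[C@H](/C=C/c3ccc(F)cn3)CC[C@H]2C)c1`: 34 nM
Compound 2 `Cc1ccc(-n2nccn2)c(C(=O)N2C[C@H](C#Cc3cncc(CO)c3)CC[C@H]2C)c1`: "not determined" (no result reported)

Compound 1 holds the only number shown in a functional assay on isolated protein for antagonist activity at Orexin receptor type 2 (Homo sapiens), read by FLIPR and calcium flux; a higher number here means a weaker inhibitor, a lower number a stronger inhibitor; in this assay compound 1 gives 34 nM. For compound 2 the entry in this assay reads "not determined" (no result reported), so there is no second number to set beside compound 1. Compound 3 `Cc1ccc(-n2nccn2)c(C(=O)N2C[C@H](C#Cc3cnccc3O)CC[C@H]2C)c1` has not yet been measured. It differs from compound 1 in one place: 2-(4-hydroxypyridin-3-yl)ethynyl in place of 2-(5-fluoropyridin-2-yl)ethenyl on a saturated ring carbon. Within the data shown here, no step between two measured compounds is available here, so the size of this change cannot be read from a neighbouring pair and rests on the change itself, which swaps the attachment point, the halogen for a hydroxyl and the double bond for a triple bond. For compound 3 a moderate loss is expected, a step of a 3.5-fold higher number from compound 1 to compound 3 (0.55 log units; beyond the scatter) that lies beyond the usual scatter but is not large. Compound 3 is expected to give 120 nM in this assay, with a range from 30 nM to 500 nM.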

Compound 3, half-maximal inhibitory concentration: 52 nM
Beside the measured number, compound 3's estimate is 2.3-fold (0.36 log units) above it, within the range that was stated.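

In this assay, 2-(4-hydroxypyridin-3-yl)ethynyl in place of 2-(5-fluoropyridin-2-yl)ethenyl on this saturated ring carbon gives a 1.5-fold higher number from compound 1 to compound 3 (0.18 log units; within the scatter), so the two compounds cannot be told apart in this read-out. The position therefore accepts a single replacement that swaps the attachment point, the fluorine for a hydroxyl and the double bond for a triple bond, with no change beyond the scatter, though the step cannot be divided among these three differences. Nothing measured on these compounds offers an explanation for the result.

The steps involving compound 2 cannot be read, as it has no number in this assay. Also open, from the compounds shown here alone, is what an amine or a carboxylic acid in place of the hydroxyl on the pyridine ring would do at this position.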